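The compounds below may be only part of what the source reports. "The series", "measured", "known", "first", "only" and "open" are said of these compounds alone.

Working notes on the series. Of the compounds shown here, two have been read so far in an ADME assay on microsomes from liver (Rattus norvegicus) for metabolic stability, read by LC-MS, using NADPH, at 37 degrees C; a lower number here means that the compound disappears faster, a higher number that the compound lasts longer. Compound 1 (`Cc1ccccc1-c1nc(CN2CCC(C(=O)NCCCN3CCC(C(C)C)CC3)CC2)c(C)o1`) stands at a half-life of 0.147 h and compound 2 (`Cc1oc(-c2ccc(F)cc2)nc1CN1CCC(C(=O)NCCCN2C[C@H](C)C[C@H](C)C2)CC1`) at 0.468 h on the same read-out. Compound 2 therefore holds the higher of the two numbers, and its gap to compound 1 lies beyond the usual scatter. These two compounds differ in more than one place, so the gap cannot be tied to any single group.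

Compound 3 (`Cc1oc(-c2c(F)cccc2F)nc1CN1CCC(C(=O)NCCCN2C[C@H](C)C[C@H](C)C2)CC1`) departs from compound 2 in one place, on an aromatic carbon of a five-membered aromatic ring with 1 nitrogen and 1 oxygen, where 2,6-difluorophenyl stands in place of 4-fluorophenyl (2,6-difluorophenyl in place of 4-fluorophenyl on an aromatic carbon). For the measured compounds named here, no measured pair isolates this change, so the data give it no size of its own. In this assay no step beyond the scatter is expected, and compound 2 at 0.468 h serves as the anchor. The expected step is estimated as a 1.1-fold lower number from compound 2 to compound 3 (0.05 log units; within the scatter) and stays inside the scatter. Compound 3 is expected at 0.42 h with a range of 0.2 h to 0.9 h as the estimate.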

Compound 3, half-life: 0.35 h
Compound 3: middle estimate off by 1.2-fold (0.08 log units), on the high side; the range from low to high includes it.
By their numbers in this assay, from the lowest: compound 1; then compounds 3 and 2 (each within the scatter of the next).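

In this assay, for the compounds shown here, 2,6-difluorophenyl in place of 4-fluorophenyl, on an aromatic carbon of the five-membered aromatic ring with 1 nitrogen and 1 oxygen, gives a 1.3-fold lower number from compound 2 to compound 3 (0.13 log units; within the scatter) and so provides the first measured step at this position. The read-out does not separate these two fluorinated phenyl groups, even though 2,6-difluorophenyl carries one more fluorine than 4-fluorophenyl, so this single pair gives no sign that the half-life depends on which of the two stands here. Nothing on hand explains the result, and the step is recorded as an observation only.

Going by these compounds alone, still open is how the half-life responds at this position to a group of another kind, such as a pyridine, a methoxyphenyl or a plain alkyl chain, since the one readable step covers only two fluorinated phenyl groups. Also open, as far as these compounds go, is the source of the gap between compound 1 and compound 2, which differ in more than one place, so that it cannot be assigned to the aromatic group or to the amine at the far end of the chain.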